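This account rests on a few compounds, and the source may have more. Where it says the series, first, only, none or still open, it means among the compounds named here.

In a functional assay on the whole organism for inhibition, with Rattus norvegicus as the target, with a stated time of 1 h (on this read-out lower numbers stand for an effect already at smaller amounts and higher numbers for an effect only at larger amounts of compound), compound 1 (`CC1(C)OC(/C=C/c2ccc(C#N)cc2)=CC1=O`) gives 12 mg/kg and compound 2 (`CC1(C)OC(/C=C/c2ccccn2)=CC1=O`) gives 10 mg/kg. For the measured compounds named here, these two values lie within the usual scatter of each other, so compound 1 stands level with the only other measured compound. Compound 3 (`CC1(C)OC(/C=C/c2ccc(F)cc2)=CC1=O`) carries fluoro in place of cyano on an aromatic carbon, para to a large group: fluoro in place of cyano on an aromatic carbon. Going by the values given here, no measured pair shows this exchange, so nothing beyond the scatter is expected in this assay. The expected step is a 1.2-fold lower number from compound 1 to compound 3 (0.08 log units; within the scatter). For compound 3 the estimated value is 10 mg/kg, with an expected range of 4 mg/kg to 25 mg/kg.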

Compound 3, dose for half-maximal effect: 11 mg/kg
The estimate for compound 3 lay 1.1-fold (0.04 log units) below the measured number; the measured number falls inside the stated range.
By their numbers in this assay, from the lowest: compounds 2, 3 and 1 (each within the scatter of the next).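

In this assay, for the compounds shown here, the exchange of cyano for fluoro on this aromatic carbon, para to a large group, gives a 1.1-fold lower number from compound 1 to compound 3 (0.04 log units; within the scatter) and provides the first step between compounds that differ in one place. At this position, the two groups therefore cannot be told apart by this read-out. No measurement shown here offers an explanation for this result. The compounds shown leave open whether an amine, a carboxylic acid or a longer chain on the same aromatic carbon would move the number beyond the scatter.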